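A few compounds are considered here, and "the series" means these few. Any claim that something is new, unique, unknown or untested is made for them only; others in the source may bear on it.

Among the measured compounds shown here, in a functional assay on SK-BR-3 cells (Homo sapiens) for antiproliferative activity, read by MTT assay, with a stated time of 72 h (on this read-out higher numbers stand for weaker inhibition and lower numbers for stronger inhibition), compound 3 `C/C=C1/[C@H](O[C@@H]2O[C@H](CO)[C@@H](O)[C@H](O)[C@H]2O)OC=C(C(=O)OC)[C@H]1CC(=O)OCCc1ccccc1` is the only compound to give a number, 11000 nM. Compound 1 `C/C=C1/[C@H](O[C@@H]2O[C@H](CO)[C@@H](O)[C@H](O)[C@H]2O)OC=C(C(=O)OC)[C@H]1CC(=O)OCCc1ccc(O)cc1` reaches only a limit of the assay, > 20000 nM. Compound 2 `C/C=C1/[C@H](O[C@@H]2O[C@H](CO)[C@@H](O)[C@H](O)[C@H]2O)OC=C(C(=O)OC)[C@H]1CC(=O)NCCC` likewise sits at a limit, > 20000 nM. Both measured steps therefore rest on that limit, the limit of > 20000 nM in this assay, at which 2 of the 3 values shown sit: an at least 1.8-fold lower number from compound 1 to compound 3 (0.25 log units; that floor lies within the scatter), and an at least 1.8-fold lower number from compound 2 to compound 3 (0.25 log units; that floor lies within the scatter), each floor lying within the scatter. Compound 4 `C/C=C1/[C@H](O[C@@H]2O[C@H](CO)[C@@H](O)[C@H](O)[C@H]2O)OC=C(C(=O)OC)[C@H]1CC(=O)OCCC` differs from compound 3 by methyl in place of phenyl on a saturated chain carbon, two bonds along the chain from an oxygen next to a carbonyl group. Of the measured steps, an at least 1.8-fold lower number from compound 2 to compound 3 (0.25 log units; that floor lies within the scatter) bears most closely on it; compound 2 too carries propyl in place of phenethyl. Removing the aromatic ring is therefore expected to raise the number, a 2.3-fold higher number from compound 3 to compound 4 (0.36 log units; beyond the scatter). Compound 4 is estimated at 25000 nM, within 8000 nM to 80000 nM, with a real chance that only a limit is recorded.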

Compound 4, half-maximal inhibitory concentration: > 15000 nM
Compound 4 was reported as a limit; the forecaster's own chance of this, stated with the estimate: 65%; the middle value does not contradict the limit.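

Among the compounds shown here, compound 3 and compound 4 share the ester and differ only in phenyl against methyl, which gives the first reading of that change alone: an at least 1.3-fold higher number from compound 3 to compound 4 (0.13 log units; that floor lies within the scatter). From the compounds shown here alone, compound 4 gives a limit of the assay and not a number, so the full size of this step stays unknown: the limit of > 15000 nM in this assay, at which 1 of the 4 values shown sits. The steps to compound 4 from compound 1 and from compound 2 cannot be read. Going by these compounds, what remains open is how a longer chain such as octyl, or an amine in place of the phenyl, would read in this assay.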